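A few compounds are considered here, and "the series" means these few. Any claim that something is new, unique, unknown or untested is made for them only; others in the source may bear on it.

Three related compounds have been examined in an ADME assay on Huh-7 cells (Homo sapiens) for cytotoxicity; on this read-out higher numbers stand for weaker inhibition of growth and lower numbers for stronger inhibition of growth. Compound 1 `COc1cc2c(=O)c(C(=O)c3ccc(C)cc3)cn(CC3CC3)c2cc1OC` comes back as "not active" (no number reported) in this assay, with no number attached to it. Compound 2 `COc1cc2c(=O)c(C(=O)OCc3ccc(Cl)cc3)cn(Cc3ccccc3)c2cc1OC` gives 28300 nM in this assay. For compound 3 `CCOC(=O)c1cn(Cc2ccc(Cl)cc2)c2cc(OC)c(OC)cc2c1=O`, this assay reports only a limit, > 15000 nM. Compound 1 thus stands among the weak growth inhibitors here, with one further value being a limit, (the limit of > 15000 nM in this assay, at which 1 of the 3 values shown sits). Compound 4 `COc1cc2c(=O)c(C(=O)c3ccc(C)cc3)cn(CC3CCCCC3)c2cc1OC` has not been measured; it differs from compound 1 by cyclohexyl in place of cyclopropyl on a saturated chain carbon bound to an aromatic nitrogen. Among the compounds with values here, with no measured step of this kind to lean on, no shift beyond the usual scatter is expected in this assay from compound 1 to compound 4, and both should stay weak. Compound 4 is therefore expected to give about 30000 nM, estimated between 10000 nM and 100000 nM, quite possibly reported only as a limit.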

Compound 4, concentration for 50% growth inhibition: 22000 nM
The estimate for compound 4 lay 1.4-fold (0.13 log units) above the measured number, within the range that was stated.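

No step can be read between compound 1 and compound 4, since in this assay compound 1 is reported as "not active" (no number reported) and compound 4 gives 22000 nM. The compounds shown leave open how far cyclohexyl in place of cyclopropyl shifts growth inhibition.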